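The source may report more compounds than this note shows. Statements on the series, on what has been measured and on what is new or still open speak of the compounds shown alone.

compound 1 `CC(C)CC[C@@H](O)C(=O)N1N=CC[C@H]1C(=O)NCc1cc(Cl)ccc1-n1cnnn1`: 47 mL.min-1.g-1
compound 2 `COC(C)(C)[C@@H](O)C(=O)N1N=CC[C@H]1C(=O)NCc1cc(Cl)ccc1-n1cnnn1`: < 12 mL.min-1.g-1

In an ADME assay on liver for metabolic stability, with Liver microsome (Homo sapiens) as the target, read by LC-MS, using microsomes (a higher number here means faster removal of the compound, a lower number slower removal), compound 2 gives < 12 mL.min-1.g-1, which is a limit of the assay and not a number. That places compound 2 at the limit of < 12 mL.min-1.g-1 in this assay, at which 1 of the 2 values shown sits.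

Compound 3 `O=C(NCc1cc(Cl)ccc1-n1cnnn1)[C@@H]1CC=NN1C(=O)[C@H](O)C1CCCCC1` differs from compound 2 in one place: cyclohexyl in place of 1-methoxy-1-methylethyl on a saturated chain carbon bound to a carbonyl carbon and an oxygen on a saturated carbon. Cyclohexyl stands in place of 1-methoxy-1-methylethyl on a saturated chain carbon bound to a carbonyl carbon and an oxygen on a saturated carbon.

Within the data shown here, one measured step bears on this place: an at least 3.9-fold lower number from compound 1 to compound 2 (0.59 log units; beyond the scatter), beyond the scatter, with 1-methoxy-1-methylethyl entering in place of isopentyl. Compound 3 gives that group up again for a group of carbon only, so much of that step is expected to reverse, with compound 1 at 47 mL.min-1.g-1 as the nearest reference. Among the measured compounds shown here, no measured compound carries cyclohexyl, so the size remains uncertain.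

The estimated change is an at least 2.5-fold higher number from compound 2 to compound 3 (0.39 log units; beyond the scatter), towards a higher number and probably beyond the scatter. For compound 3 the expected value is 30 mL.min-1.g-1, with an estimated range of 13 mL.min-1.g-1 to 70 mL.min-1.g-1.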

Compound 3, intrinsic clearance in microsomes: 63 mL.min-1.g-1
Beside the measured number, compound 3's estimate is 2.1-fold (0.32 log units) below it; the range from low to high includes it.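

In this assay, cyclohexyl on the saturated chain carbon bound to a carbonyl carbon and an oxygen on a saturated carbon brings the number back up, with an at least 5.2-fold higher number from compound 2 to compound 3 (0.72 log units; beyond the scatter). Against the open-chain isopentyl, the ring gives a 1.3-fold higher number from compound 1 to compound 3 (0.13 log units; within the scatter), so the two groups of carbon only cannot be told apart here, and among the three compounds only 1-methoxy-1-methylethyl goes with the low number. For compound 2 the value is a limit of the assay, so the step to compound 3 gives only a lower bound on the size of the change: the limit of < 12 mL.min-1.g-1 in this assay, at which 1 of the 3 values shown sits.

Still open is whether the low number goes with the oxygen of 1-methoxy-1-methylethyl or with its branched carbon, as the compounds shown change the two together; tert-butyl at this place would keep the branching without the oxygen, and 2-methoxyethyl would keep the oxygen without the branching. Also open, from the compounds shown here alone, is whether tetrahydropyranyl, a six-membered ring holding an oxygen, would stand with cyclohexyl or with 1-methoxy-1-methylethyl in this assay.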